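The source may hold more compounds than are shown below. What is called first, only, known or untested is meant among the compounds shown, and "the series" means these compounds.

Values in a functional assay on HCT-116 cells (Homo sapiens) for antiproliferative activity, read by sulforhodamine B assay, with a stated time of 72 h; a lower number here means a stronger inhibitor, a higher number a weaker inhibitor:

- compound 1 `Cn1ncc(Cl)c1-c1cc(C(=O)N[C@@H]2CN[C@H](CCN3CCC(O)CC3)C[C@H]2c2ccc(Cl)c(Cl)c2)oc1Cl`: 13700 nM
- compound 2 `Cn1ncc(Cl)c1-c1cc(C(=O)N[C@@H]2CN[C@H](CCO)C[C@H]2c2ccc(F)c(F)c2)oc1Cl`: 360 nM
- compound 3 `CC(=O)OCC[C@@H]1C[C@@H](c2ccc(F)c(F)c2)[C@H](NC(=O)c2cc(-c3c(Cl)cnn3C)c(Cl)o2)CN1`: 690 nM

Compound 1 gives the highest number of the three in this assay; compound 3 is the nearest and compound 2 the furthest, and both gaps lie beyond the scatter. Going by the values given here, compound 2 and compound 3 share the shared core, differ from compound 1 in the aryl ring as well as in the chain, and no single step to compound 1 exists for either.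

Compound 4 `Cn1ncc(Cl)c1-c1cc(C(=O)N[C@@H]2CN[C@H](CC(=O)NCCO)C[C@H]2c2ccc(Cl)c(Cl)c2)oc1Cl` keeps the aryl ring and core of compound 1 and alters only the chain: (2-hydroxyethyl)carbamoyl in place of (4-hydroxypiperidin-1-yl)methyl on a saturated chain carbon bound to a saturated ring carbon

Among the compounds with values here, the one measured step, a 1.9-fold higher number from compound 2 to compound 3 (0.28 log units; within the scatter), concerns a change on an oxygen in a different chain and does not bear on this move; it shows only that a small change at the chain end left the number within the scatter. The pair compound 1 and compound 2, whose chains differ in the same region though two changes separate them, shows a large gap in favour of the short hydroxyl-bearing chain. For compound 4 a lower number than compound 1 is therefore expected, of the size a 3.9-fold lower number from compound 1 to compound 4 (0.59 log units; beyond the scatter), with wide uncertainty. Compound 4 is estimated at 3500 nM, in the range 800 nM to 14000 nM.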

Compound 4, half-maximal inhibitory concentration: 670 nM
Estimate against measurement, compound 4: 5.2-fold (0.72 log units) above, outside the stated range (below it).
By their numbers in this assay, from the lowest: compounds 2, 4 and 3 (each within the scatter of the next); then compound 1.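

Notes on the chain position, on a saturated chain carbon bound to a saturated ring carbon. In this assay, going by these compounds alone, with the aryl ring and the shared core held fixed, (2-hydroxyethyl)carbamoyl in place of (4-hydroxypiperidin-1-yl)methyl gives a 20-fold lower number from compound 1 to compound 4 (1.31 log units; beyond the scatter), so the chain change alone moves the number by a large step, which the earlier compounds could not show, as they differ from compound 1 in the aryl ring as well. The change replaces a six-membered ring with an open chain, adds a double bond outside aromatic rings and brings 2 hydrogen-bond donors in place of 1, and the single step does not separate these features; no measurement shown bears on why the number moves.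

Going by these compounds, it remains open which feature carries the step, and a carboxylic acid or a longer chain ending in an amine at this position would test how far the chain end can vary. On these data alone, it is also open whether the same chain exchange gives a step of similar size on the aryl ring of compound 2.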